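Working notes: from compound 3 to compound 4 in cytotoxicity

The compounds below may be only part of what the source reports. "The series", "measured", "known", "first", "only" and "open" are said of these compounds alone.

Measured so far:
compound 1 `C=C(Br)C(=O)Nc1cccc(/C=C2\SC(=O)N(Cc3ccc(C)cc3)C2=O)c1` — in a functional assay on HeLa cells (Homo sapiens) for cytotoxicity, read by cell counting, with a stated time of 4 days (on this read-out higher numbers stand for weaker inhibition and lower numbers for stronger inhibition), compound 1 gives 1200 nM
compound 2 `Nc1cccc(/C=C2\SC(=O)N(Cc3ccc(C(F)(F)F)cc3)C2=O)c1` — in this assay compound 2 reaches only a limit, > 250000 nM
compound 3 `C=C(Br)C(=O)Nc1cccc(/C=C2\SC(=O)N(Cc3ccc(C(C)(C)C)cc3)C2=O)c1` — in this assay compound 3 gives 2800 nM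

Among the two numbers shown, compound 3 has the higher one; its nearest neighbour is compound 1, separated by a 2.3-fold higher number from compound 1 to compound 3 (0.37 log units; beyond the scatter), a modest step that goes beyond the scatter. Compound 2 sits at the limit of > 250000 nM in this assay, at which 1 of the 3 values shown sits, which is a limit and not a number. Compound 2 also differs from the other compounds in more than one place, so no single step can be read from it.

Compound 4 `C=C(Br)C(=O)Nc1cccc(/C=C2\SC(=O)N(Cc3ccc(C(F)(F)F)cc3)C2=O)c1` differs from compound 3 by trifluoromethyl in place of tert-butyl on an aromatic carbon. Going by the values given here, the only measured step at this aromatic carbon is a 2.3-fold higher number from compound 1 to compound 3 (0.37 log units; beyond the scatter); it swaps one four-carbon group for a one-carbon group and gave a modest rise in the number. The present change keeps the count of heavy atoms the same and leaves donors and acceptors unchanged, so the expectation is a step no larger than that one, if anything a slight fall in the number, close to the scatter. Compound 4 is therefore estimated at 1800 nM, with a range from 700 nM to 5000 nM. The step this implies is expected to be a 1.6-fold lower number from compound 3 to compound 4 (0.19 log units; within the scatter).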

Compound 4, half-maximal inhibitory concentration: 820 nM
For compound 4 the middle estimate is 2.2-fold (0.34 log units) above the measured one, within the range that was stated.
By their numbers in this assay, from the lowest: compounds 4 and 1 (each within the scatter of the next); then compound 3. At a limit, above all of these: compound 2.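

In this assay, trifluoromethyl in place of tert-butyl at the same heavy-atom count gives a 3.4-fold lower number from compound 3 to compound 4 (0.53 log units; beyond the scatter), while trifluoromethyl in place of methyl gives a 1.5-fold lower number from compound 1 to compound 4 (0.17 log units; within the scatter), so among the three groups at this aromatic carbon, tert-butyl alone is set apart by a step beyond the scatter, and that step is modest. Going by these compounds alone, with trifluoromethyl held constant, a change at a different place, (1-bromoethenyl)carbonyl in place of hydrogen on the nitrogen, gives an at least 300-fold lower number from compound 2 to compound 4 (2.48 log units; beyond the scatter), which is the first single-place reading for that group and far exceeds any step at the aromatic carbon. Compound 2 stands at a limit and not at a number: the limit of > 250000 nM in this assay, at which 1 of the 4 values shown sits.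

From the compounds shown here alone, it remains open whether a methoxy group, a carboxylic acid or an amine at this aromatic carbon would stay as close to compound 1, compound 3 and compound 4 as these three stay to one another. Going by these compounds, it also remains open whether a plain acetyl on the nitrogen, without the bromine and the terminal double bond, would keep any of the large step seen with the (1-bromoethenyl)carbonyl group.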